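Nitro for Bromo Across Two Related Bis-indolyl Cores

The compounds below may be only part of what the source reports. "The series", "measured", "known", "first", "only" and "open" are said of these compounds alone.

The measured compounds, all in a functional assay on MCF7 cells (Homo sapiens) for inhibition, read by MTT assay, with a stated time of 48 h; on this read-out higher numbers stand for weaker inhibition and lower numbers for stronger inhibition:
Compound 1 `O=[N+]([O-])c1ccc2[nH]cc(C(c3ccc(Br)cc3)c3c[nH]c4ccc([N+](=O)[O-])cc34)c2c1` gives > 100000 nM, which is a limit of the assay and not a number.
Compound 2 `O=[N+]([O-])c1ccc(C(c2c[nH]c3ccc([N+](=O)[O-])cc23)c2c[nH]c3ccc([N+](=O)[O-])cc23)cc1` gives 22500 nM.
Compound 3 `N#Cc1ccc2[nH]cc(C(c3ccc(Br)cc3)c3c[nH]c4ccc(C#N)cc34)c2c1` gives 27100 nM.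

Compound 1 and compound 2 share a core and differ in one place: nitro in place of bromo on an aromatic carbon. That change gave an at least 4.4-fold lower number from compound 1 to compound 2 (0.64 log units; beyond the scatter). The size of the step rests on (the limit of > 100000 nM in this assay, at which 1 of the 3 values shown sits), so only its lower bound is known. Compound 3 carries a different core; the difference between the core of compound 1 and the core of compound 3 is not broken down here. Compound 3 and compound 2 sit within the scatter of each other.

Compound 4 `N#Cc1ccc2[nH]cc(C(c3ccc([N+](=O)[O-])cc3)c3c[nH]c4ccc(C#N)cc34)c2c1` is not yet measured. It differs from compound 3 by nitro in place of bromo on an aromatic carbon. Within the data shown here, the place lines of the two changes agree word for word, so this is the same change as the one from compound 1 to compound 2. If it behaves alike, the number for compound 4 should come out clearly lower than that of compound 3. He expects a step of about a 3.4-fold lower number from compound 3 to compound 4 (0.53 log units; beyond the scatter), resting on an at least 4.4-fold lower number from compound 1 to compound 2 (0.64 log units; beyond the scatter) as the only measured instance of this change, with the caution that its true size is hidden behind (the limit of > 100000 nM in this assay, at which 1 of the 3 values shown sits). On that basis compound 4 is estimated at 8000 nM, with a plausible range from 2500 nM to 30000 nM, to be checked once the measurement is in hand.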

Compound 4, half-maximal inhibitory concentration: 23600 nM
The estimate for compound 4 lay 3.0-fold (0.47 log units) below the measured number; the range from low to high includes it.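

In this assay, the change from 4-bromophenyl to 4-nitrophenyl on the core of compound 3 gave a 1.1-fold lower number from compound 3 to compound 4 (0.06 log units; within the scatter), so this core shows no measurable gain from the change. The change therefore did not carry over in size from the core of compound 1 to the core of compound 3, and its effect in this series depends on the core it sits on: the same change on two cores in this assay, an at least 4.4-fold lower number (0.64 log units; beyond the scatter) from compound 1 to compound 2 and a 1.1-fold lower number (0.06 log units; within the scatter) from compound 3 to compound 4, at least 3.8-fold (0.58 log units) apart, beyond the scatter of two such steps This does not show how large the gap between the two steps really is, nor what in the two cores sets them apart, since each core offers only one pair and compound 1 rests on a limit of the assay and not a number: the limit of > 100000 nM in this assay, at which 1 of the 4 values shown sits.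

The compounds shown leave open whether a third core would follow the core of compound 1, the core of compound 3, or neither. They also leave open how an amine or a carboxylic acid in the same place on the aromatic ring, in place of the bromo or nitro group, would read on each of the two cores.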